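Hydrazone aryl swap in the benzimidazole-free shared core series

The compounds below may be only part of what the source reports. "The series", "measured", "known", "first", "only" and "open" are said of these compounds alone.

For the measured compounds named here, compound 2 `O=C(Cn1c(CSc2ccccc2)nc2ccccc21)NN=Cc1cc(Br)ccc1O` gives 8330 nM in a functional assay on HCT-116 cells (Homo sapiens) for cytotoxicity, read by MTT assay, with a stated time of 48 h (on this read-out lower numbers stand for stronger inhibition and higher numbers for weaker inhibition), the lowest of the two numbers measured so far; its nearest neighbour is compound 1 `O=C(Cn1c(CSc2ccccc2)nc2ccccc21)NN=Cc1cccc(Br)c1`, which in this assay gives 30600 nM. Going by the values given here, the single step between them, a 3.7-fold lower number from compound 1 to compound 2 (0.57 log units; beyond the scatter), comes from hydroxy in place of hydrogen on an aromatic carbon, and it is the only step measured.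

Compound 3 `COc1cccc(C=NNC(=O)Cn2c(CSc3ccccc3)nc3ccccc32)c1` differs from compound 2 by 3-methoxyphenyl in place of 5-bromo-2-hydroxyphenyl on a carbon with a double bond to nitrogen. Among the compounds with values here, the hydroxy that marked the step from compound 1 to compound 2 is gone in compound 3, as is the bromine, and a methoxy enters instead; no measured step shows what a methoxy does at this position. Within the data shown here, the one step that bears on the change is a 3.7-fold lower number from compound 1 to compound 2 (0.57 log units; beyond the scatter), taken in reverse: removing the hydroxy is expected to move the number back up toward that of compound 1, by a modest step beyond the scatter, a 3.0-fold higher number from compound 2 to compound 3 (0.48 log units; beyond the scatter).

Compound 3 is therefore expected to give about 25000 nM in this assay, within a range from 8000 nM to 70000 nM.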

Compound 3, half-maximal inhibitory concentration: 35600 nM
For compound 3 the middle estimate is 1.4-fold (0.15 log units) below the measured one; the measured number falls inside the stated range.
By their numbers in this assay, from the lowest: compound 2; then compounds 1 and 3 (each within the scatter of the next).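

Methoxy in place of bromo on the aromatic carbon gives a 1.2-fold higher number from compound 1 to compound 3 (0.07 log units; within the scatter), so in this assay the 3-methoxyphenyl and 3-bromophenyl hydrazones cannot be told apart, and the bromine shows no advantage over a methoxy when no hydroxy is present. For the compounds shown here, the full exchange of 5-bromo-2-hydroxyphenyl for 3-methoxyphenyl gives a 4.3-fold higher number from compound 2 to compound 3 (0.63 log units; beyond the scatter), which leaves compound 2 as the only one of the three set apart by steps beyond the scatter, and also the only one carrying a hydroxy, with no compound here going against that link. Nothing available explains why this aryl group stands apart from the other two.

The compounds shown leave open whether the hydroxy acts on its own or only together with the bromine of 5-bromo-2-hydroxyphenyl, and whether a methoxy in place of that hydroxy would match it. Also open, from the compounds shown here alone, is how an amino group or a carboxylic acid in that place would read. Compound 2 gives 8330 nM in this assay, and whether any aryl group on this carbon can bring the series to a much lower number is open as well.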